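Compound 4 notes: methyl to chloromethyl on compound 3

This account rests on a few compounds, and the source may have more. Where it says the series, first, only, none or still open, it means among the compounds named here.

Measured so far in a functional assay on HepG2 cells (Homo sapiens) for inhibition, read by XTT assay, with a stated time of 72 h; a lower number here means a stronger inhibitor, a higher number a weaker inhibitor:
- compound 1, `CC(=O)c1sc(NNS(=O)(=O)c2ccc(C)cc2)nc1C`, 8770 nM
- compound 2, `CCOC(=O)c1sc(NNS(=O)(=O)c2ccc(C)cc2)nc1C`, a limit of the assay, < 4510 nM
- compound 3, `CC(=O)N(c1nc(C)cs1)N(C(C)=O)S(=O)(=O)c1ccc(C)cc1`, 7360 nM

Compound 3 gives the lowest of the two numbers in this assay; the nearest is compound 1, whose number is higher by a margin within the scatter, so no order between compound 3 and compound 1 is claimed. The value of compound 2 is a limit, not a number, and compound 2 sits on the limit described by the limit of < 4510 nM in this assay, at which 1 of the 3 values shown sits.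

Compound 4 is `CC(=O)N(c1nc(CCl)cs1)N(C(C)=O)S(=O)(=O)c1ccc(C)cc1`. It differs from compound 3 by chloro in place of hydrogen on a saturated chain carbon bound to an aromatic carbon.

Among the compounds with values here, the only measured single-point step is an at least 1.9-fold lower number from compound 1 to compound 2 (0.28 log units; that floor lies within the scatter), which concerns a different change, ethoxy in place of methyl on a carbonyl carbon, and reaches only a limit that lies within the scatter. Within the data shown here, no measured step exchanges hydrogen for chloro on a saturated chain carbon, so nothing here supports a move beyond the scatter in either direction for compound 4.

The estimate for compound 4 in this assay is therefore 7000 nM, with a range from 2500 nM to 20000 nM, and the expected step of a 1.1-fold lower number from compound 3 to compound 4 (0.02 log units; within the scatter) is no change beyond the scatter.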

Compound 4, half-maximal inhibitory concentration: > 62300 nM
Compound 4: no number, only a limit; the forecaster's own chance of this, stated with the estimate: 15%; middle value at least 8.9-fold (0.94 log units) away from the limit.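

Changing methyl to chloromethyl on compound 3 gives an at least 8.4-fold higher number from compound 3 to compound 4 (0.92 log units; beyond the scatter) in this assay, the first step in this series shown to lie beyond the scatter. A single chlorine on this saturated chain carbon bound to an aromatic carbon is therefore enough to weaken inhibition, so this position is not indifferent to substitution, which the change at the carbonyl carbon between compound 1 and compound 2 could not show. The value of compound 4 is a limit of the assay, not a number: the limit of > 62300 nM in this assay, at which 1 of the 4 values shown sits.

The compounds shown do not separate an effect of chloro itself from that of any other replacement of hydrogen at this carbon, and a hydroxymethyl or aminomethyl group there would test this. Going by these compounds, whether the same change acts alike on the core of compound 1 also remains open.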